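Ring Size Change on a Benzylic Amine

The compounds below may be only part of what the source reports. "The series", "measured", "known", "first", "only" and "open" are said of these compounds alone.

Measured so far:
compound 1 `CN1CCN(CCCN(c2nc3cc(Cl)c(Cl)cc3[nH]2)[C@@H]2CC[C@]3(c4cccc(C#N)c4)C[C@H]23)CC1`: 6.8 nM
compound 2 `CN1CCN(CCCN(c2nc3cc(F)c(F)cc3[nH]2)[C@@H]2CC[C@]3(c4cccc(CN5CCCC5)c4)C[C@@H]3C2)CC1`: 25.7 nM

In an assay on isolated protein for binding affinity to melanin-concentrating hormone receptor 1 (Homo sapiens) (on this read-out lower numbers stand for stronger inhibition and higher numbers for weaker inhibition), compound 1 gives 6.8 nM, and in this assay compound 2 gives 25.7 nM. Compound 2 therefore carries the higher of the two numbers, and the gap to compound 1 lies beyond the usual scatter. The two compounds differ in more than one place, so no single structural change can be tied to that gap.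

Compound 3 `CN1CCN(CCCN(c2nc3cc(F)c(F)cc3[nH]2)[C@@H]2CC[C@]3(c4cccc(CN5CCCCC5)c4)C[C@@H]3C2)CC1` is not yet measured. Compared with compound 2 it changes only one thing: piperidin-1-yl in place of pyrrolidin-1-yl on a saturated chain carbon bound to an aromatic carbon. Widening a saturated nitrogen ring by one carbon in this way leaves the donor and acceptor count untouched. Going by the values given here, no measured pair here isolates this change, so nothing in the data points in a direction. The expectation for the step from compound 2 to compound 3 is therefore a change of about a 1.0-fold lower number from compound 2 to compound 3 (0.01 log units; within the scatter), which is none beyond the scatter. On that basis compound 3 is estimated at 25 nM, with a likely range from 10 nM to 60 nM.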

Compound 3, inhibition constant: 405 nM
Compound 3: the middle estimate sits 16-fold (1.21 log units) below what was measured; measured number outside the range, above it.
By their numbers in this assay, from the lowest: compound 1; then compound 2; then compound 3.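

In this assay, replacing pyrrolidin-1-yl with piperidin-1-yl gives a 16-fold higher number from compound 2 to compound 3 (1.20 log units; beyond the scatter) and so shows that this place on the molecule, the saturated chain carbon bound to an aromatic carbon, does not accept any saturated nitrogen ring equally. The change leaves the donor and acceptor counts as they were, which means those counts alone do not predict the result for this pair. Going by these compounds alone, compound 1 and compound 2 differ in more than one place and could not show this, while compound 2 and compound 3 give the first direct reading of a single change, although no measurement here explains the size of the step.

A single pair of rings cannot show whether the numbers follow ring size in general, and an azetidin-1-yl ring, a morpholin-4-yl ring or an open-chain dimethylamino group at the same place would help to test that. Going by these compounds, it also remains open whether swapping these two rings would produce a step of similar size on the core of compound 1, which carries a nitrile where compound 2 has its ring-bearing chain.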